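The source may hold more compounds than are shown below. What is called first, only, known or untested is meant among the compounds shown, and "the series" means these compounds.

Compound 1, drawn as `Cc1ccc(OCC(=O)NNC(=O)c2cc3ccccc3oc2=O)c(C(=O)c2ccccc2Br)c1`, carries a bromine on its pendant aryl ring, while compound 2, drawn as `Cc1ccc(OCC(=O)NNC(=O)c2cc3ccccc3oc2=O)c(C(=O)c2ccccc2)c1`, is the same molecule with that bromine replaced by hydrogen. Among the measured compounds shown here, in a functional assay on DLA cells (Mus musculus) for cytotoxicity, read by MTT assay, with a stated time of 48 h (a lower number here means a stronger inhibitor, a higher number a weaker inhibitor), compound 1 gives 10000 nM, the lowest of the two numbers known so far. For the measured compounds named here, compound 2 gives 86400 nM in this assay, and the only known step, an 8.6-fold higher number from compound 1 to compound 2 (0.94 log units; beyond the scatter), shows that losing the bromine weakens the compound.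

Compound 3, drawn as `Cc1ccc(OCC(=O)NNC(=O)c2cc3ccccc3oc2=O)c(C(=O)c2cccc(Br)c2)c1`, keeps the bromine but moves it: 3-bromophenyl in place of 2-bromophenyl on a carbonyl carbon. Going by the values given here, no measured step covers such a shift in position, so the only guide is that the bromine itself matters, as the step between compound 1 and compound 2 shows. A change much smaller than that step is therefore expected, with no firm direction. For compound 3 the expected step from compound 1 is a 1.5-fold higher number from compound 1 to compound 3 (0.18 log units; within the scatter), giving an estimate of 15000 nM, within a range from 4000 nM to 60000 nM.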

Compound 3, half-maximal inhibitory concentration: 68500 nM
For compound 3 the middle estimate is 4.6-fold (0.66 log units) below the measured one, outside the stated range (above it).
By their numbers in this assay, from the lowest: compound 1; then compounds 3 and 2 (each within the scatter of the next).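

Where the bromine sits counts, not merely whether it is present: 3-bromophenyl in place of 2-bromophenyl on the carbonyl carbon gives a 6.9-fold higher number from compound 1 to compound 3 (0.84 log units; beyond the scatter) in this assay. Bromo in place of hydrogen on an aromatic carbon gives only a 1.3-fold lower number from compound 2 to compound 3 (0.10 log units; within the scatter), so among these compounds the benefit of bromine appears with the 2-bromophenyl group and not with the 3-bromophenyl group. Nothing measured here explains why the two placements differ.

The compounds shown leave open what 4-bromophenyl would give, and whether 2-chlorophenyl or 2-methoxyphenyl would match 2-bromophenyl. Going by these compounds, it also remains open whether the same pattern would hold in any assay other than this assay.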